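The source may report more compounds than this note shows. Statements on the series, on what has been measured and on what is new or still open speak of the compounds shown alone.

Working notes on the series.

Compound 1 `COC(=O)[C@@]1(C)CCC=C2[C@@H]1CC[C@@H](C)[C@]2(C)Cc1c[nH]c2ccccc12` gives 4200 nM in a functional assay on T47D cells (Homo sapiens) for inhibition, read by sulforhodamine B assay, with a stated time of 48 h; on this read-out higher numbers stand for weaker inhibition of growth and lower numbers for stronger inhibition of growth. Compound 2 `COC(=O)[C@@]1(C)CCC=C2[C@@H]1CC[C@@H](C)[C@]2(C)Cc1c[nH]c2ccc(C)cc12` gives 20000 nM in this assay. The change between them is methyl in place of hydrogen on an aromatic carbon and the step it made is a 4.8-fold higher number from compound 1 to compound 2 (0.68 log units; beyond the scatter).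

Compound 3 `COC(=O)[C@@]1(C)CC[C@@H]2C3=C1CC[C@@H](C)[C@]3(C)Cc1c2[nH]c2ccccc12` gives 3400 nM in this assay; its value and that of compound 1 lie within the scatter of each other, while compound 2 gives a higher number than compound 3. The difference between the core of compound 3 and the core of compound 1 is not broken down here.

Compound 4 `COC(=O)[C@@]1(C)CC[C@@H]2C3=C1CC[C@@H](C)[C@]3(C)Cc1c2[nH]c2c(C)cccc12` is not yet measured. Against compound 3 the change is methyl in place of hydrogen on an aromatic carbon. Among the measured compounds shown here, this is the same kind of change as the one from compound 1 to compound 2, but not the same: there the aromatic carbon was part of a fused or bridged system of two rings, meta to a fused ring and para to a fused ring; here it is part of a fused or bridged system of five rings, ortho to a fused ring and meta to a fused ring.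

For the measured compounds named here, for compound 4 a weakening of growth inhibition is expected, and the expected step in this assay is a 3.2-fold higher number from compound 3 to compound 4 (0.51 log units; beyond the scatter), put beside the one measured step of this kind because a 4.8-fold higher number from compound 1 to compound 2 (0.68 log units; beyond the scatter) ran that way for the one measured example of methyl in place of hydrogen on an aromatic carbon. Since the place is not the same, the expectation is held loosely. Compound 4 is thus estimated at 11000 nM in this assay, within a range from 3500 nM to 35000 nM.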

Compound 4, concentration for 50% growth inhibition: 23000 nM
For compound 4 the middle estimate is 2.1-fold (0.32 log units) below the measured one; measured number inside the range.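

Methyl in place of hydrogen on an aromatic carbon weakened growth inhibition on the core of compound 3, as it did on the core of compound 1, giving a 6.8-fold higher number from compound 3 to compound 4 (0.83 log units; beyond the scatter) in this assay. The two steps run the same way, and their sizes cannot be told apart: the same change on two cores in this assay, a 4.8-fold higher number (0.68 log units; beyond the scatter) from compound 1 to compound 2 and a 6.8-fold higher number (0.83 log units; beyond the scatter) from compound 3 to compound 4, 1.4-fold (0.15 log units) apart, within the scatter of two such steps. This shows that, for these two pairs, the penalty carried over from one core to the other, but two pairs do not establish a rule for the series; the aromatic carbon bearing the methyl is also not the same in the two pairs, so the effect of the core cannot be separated from that of the place, and the data give no reason for the loss.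

Methyl is the only group shown on these aromatic carbons, so it remains open whether fluorine, a methoxy group, an amine or a longer chain such as ethyl would also give a higher number on either core. Also open, as far as these compounds go, is whether the methyl ester shared by all four compounds could give way to a carboxylic acid or an amide, and whether such a change would carry from one core to the other.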